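The compounds below may be only part of what the source reports. "The series", "measured", "known", "first", "only" and "open" are said of these compounds alone.

Compound 1, `Cc1cc(C(=O)O)ccc1-c1noc(-c2ccc(C3CCCCC3)cc2)n1`, carries a carboxy group directly on the aromatic ring. In a functional assay on CHO cells for agonist activity at sphingosine 1-phosphate receptor 5 (Homo sapiens), read by GTPgammaS binding (on this read-out higher numbers stand for an effect only at larger amounts of compound and lower numbers for an effect already at smaller amounts), compound 1 reaches only the limit of the assay, > 10000 nM, so no number is known for it. Compound 2, `Cc1cc(CC(=O)O)ccc1-c1noc(-c2ccc(C3CCCCC3)cc2)n1`, has the acid moved out by one chain carbon, and in this assay compound 2 gives 4000 nM. This move, an at least 2.5-fold lower number from compound 1 to compound 2 (0.39 log units; beyond the scatter), took the compound from a limit to a measurable number. Compound 3, `Cc1cc(-c2nc(-c3ccc(CCC(=O)O)cc3C)no2)ccc1OC(C)C`, is built on a different core but carries the acid two chain carbons away from the ring; in this assay compound 3 gives 210 nM. Of the two numbers shown, compound 2 stands highest, and the gap to compound 3 lies beyond the usual scatter.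

Compound 4, `Cc1cc(CCCC(=O)O)ccc1-c1noc(-c2ccc(C3CCCCC3)cc2)n1`, keeps the core of compound 2 and lengthens the acid chain: 2-carboxyethyl in place of carboxy on a saturated chain carbon bound to an aromatic carbon. Among the measured compounds shown here, the one measured step that bears on this, an at least 2.5-fold lower number from compound 1 to compound 2 (0.39 log units; beyond the scatter), shows that pushing the acid further from the ring lowered the number. Compound 3, with its acid at the same distance as in compound 4, also sits low. A further lowering is therefore expected, a 5.0-fold lower number from compound 2 to compound 4 (0.70 log units; beyond the scatter), and compound 4 is estimated at 800 nM, between 200 nM and 3000 nM.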

Compound 4, half-maximal effective concentration: 840 nM
The estimate for compound 4 lay 1.1-fold (0.02 log units) below the measured number; low and high end bracket the measured number.
By their numbers in this assay, from the lowest: compound 3; then compound 4; then compound 2. At a limit, above all of these: compound 1.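

Among the compounds shown here, on the shared core, the change from carboxymethyl to 3-carboxypropyl gives, in this assay, the first comparison in which both ends are real numbers: a 4.8-fold lower number from compound 2 to compound 4 (0.68 log units; beyond the scatter). The earlier lowering started from a limit, so its true size stayed unknown, whereas this step shows that the number keeps falling as the chain grows, and neither compound 1, compound 2 nor compound 4 goes against that order. The whole distance from the carboxy group on an aromatic carbon to the 3-carboxypropyl chain, an at least 11-fold lower number from compound 1 to compound 4 (1.07 log units; beyond the scatter), can be read only as a bound, because compound 1 sits at a limit: the limit of > 10000 nM in this assay, at which 1 of the 4 values shown sits.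

Three points on one core show a direction, but not where it ends: a longer chain, such as 4-carboxybutyl, might lower the number further or raise it again. From the compounds shown here alone, it also remains open whether the carboxylic acid itself matters at the end of this chain, or whether an amine or a plain ester there would give a similar number.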